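This account rests on a few compounds, and the source may have more. Where it says the series, first, only, none or still open, it means among the compounds named here.

Measured in the series:
- compound 1, `O=C(O)Cc1sc(C(c2ccc(F)cc2)c2ccc(F)cc2)nc1-c1ccc(Cl)cc1`: 80%
- compound 2, `O=C(O)Cc1sc(C(c2ccc(F)cc2)c2ccc(F)cc2)nc1-c1cccc(F)c1`: 80%
- compound 3, `NS(=O)(=O)c1cccc(-c2nc(C(c3ccc(F)cc3)c3ccc(F)cc3)sc2CC(=O)O)c1`: 55%

In an in vitro functional assay on HEK285-7 cells for antagonist activity at prostaglandin D2 receptor 2 (Homo sapiens), read by BRET and beta-arrestin recruitment (on this read-out higher numbers stand for larger maximal responses and lower numbers for smaller maximal responses), compound 3 stands lowest of the three numbers, with compound 1 and compound 2 both beyond the scatter above it. Compound 4 is `O=C(O)Cc1sc(C(c2ccc(F)cc2)c2ccc(F)cc2)nc1-c1ccoc1`. Against compound 3 it differs in one place: furan-3-yl in place of 3-sulfamoylphenyl on an aromatic carbon.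

Within the data shown here, two measured steps bear on this change, since both end at compound 3 and both bring the 3-sulfamoylphenyl group in: a number 25 percentage points lower from compound 1 to compound 3 (beyond the scatter) and a number 25 percentage points lower from compound 2 to compound 3 (beyond the scatter). The third step, no change at the digits printed from compound 1 to compound 2 (within the scatter), shows that exchanging one halophenyl group for another at the same ring carbon leaves the maximal response flat. Among the measured compounds shown here, no measured compound carries a furan-3-yl group, so the size of the entering group is untested here. Taking the 3-sulfamoylphenyl group out is expected to undo the modest drop seen on its entry, so a modest rise is expected, a number 20 percentage points higher from compound 3 to compound 4 (beyond the scatter), with the furan-3-yl group carrying some uncertainty of its own. Compound 4 is therefore estimated at 75%, in the range 55% to 95%.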

Compound 4, largest response reached (reported as efficacy), in percent of the reference or control that the assay uses: 80%
Beside the measured number, compound 4's estimate is 5 percentage points below it; the range from low to high includes it.
By their numbers in this assay, from the lowest: compound 3; then compounds 1, 2 and 4 (each within the scatter of the next).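

In this assay, furan-3-yl restores the response lost with 3-sulfamoylphenyl, giving a number 25 percentage points higher from compound 3 to compound 4 (beyond the scatter). The comparisons with the halophenyl compounds give no change at the digits printed from compound 2 to compound 4 (within the scatter) and no change at the digits printed from compound 1 to compound 4 (within the scatter), so this position, on an aromatic carbon next to the ring nitrogen, accepts a five-membered aromatic ring with 1 hetero atom as well as the two six-membered halophenyl groups, and among the four compounds only 3-sulfamoylphenyl goes with a lower maximal response. The data offer no explanation for why this one group stands apart.

As far as these compounds go, whether the lower response follows the sulfamoyl group itself remains open, and a phenyl ring carrying an amine or a carboxylic acid at this position would test how specific it is. Also open, from the compounds shown here alone, is whether the response stays flat with a non-aromatic group here, such as a piperidine ring or a short alkyl chain.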